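The source may report more compounds than this note shows. Statements on the series, on what has been measured and on what is new or still open speak of the compounds shown alone.

Measured so far in a functional assay on MCF7 cells (Homo sapiens) for cytotoxicity, read by MTT assay, with a stated time of 48 h; a higher number here means a weaker inhibitor, a lower number a stronger inhibitor:

Compound 1, `O=C(CSc1nnc(-c2ccncc2)o1)N/N=C/c1ccccc1` — 14600 nM
Compound 2, `O=C(CSc1nnc(-c2ccncc2)o1)N/N=C/c1ccc(Cl)cc1` — 15300 nM
Compound 3, `O=C(CSc1nnc(-c2ccncc2)o1)N/N=C/c1ccc([N+](=O)[O-])cc1` — 31800 nM

All three compounds share one core and differ only in the substituent on the benzene ring of the hydrazone. Compound 2 gives the second highest of the three numbers: its value and that of compound 1 sit within the scatter of each other, so no order between them can be claimed, while compound 3 stands apart with a higher number, that is, weaker inhibition.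

The step from compound 2 to compound 4, `COc1cccc(/C=N/NC(=O)CSc2nnc(-c3ccncc3)o2)c1`, is 3-methoxyphenyl in place of 4-chlorophenyl on a carbon with a double bond to nitrogen.

Among the compounds with values here, two measured steps touch this position. Going from compound 1 to compound 2, a chloro in place of hydrogen, gave a 1.0-fold higher number from compound 1 to compound 2 (0.02 log units; within the scatter). Going from compound 2 to compound 3, a nitro in place of chloro, gave a 2.1-fold higher number from compound 2 to compound 3 (0.32 log units; beyond the scatter). So a small substituent on that ring left the number unchanged, and only the nitro moved it modestly. No methoxy group has been tested here, so the expectation rests on these two steps alone: in this assay the change to compound 4 is expected to give a 1.0-fold higher number from compound 2 to compound 4 (0.02 log units; within the scatter), most likely nothing beyond the scatter.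

Compound 4 is therefore estimated at 16000 nM, with a range from 8000 nM to 34000 nM.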

Compound 4, half-maximal inhibitory concentration: 13800 nM
Beside the measured number, compound 4's estimate is 1.2-fold (0.06 log units) above it, and the stated range covers the measured number.
By their numbers in this assay, from the lowest: compounds 4, 1 and 2 (each within the scatter of the next); then compound 3.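

In this assay, 3-methoxyphenyl differs from 4-chlorophenyl both in the group and in the ring position its name gives, yet the swap shows a 1.1-fold lower number from compound 2 to compound 4 (0.04 log units; within the scatter), and adding the methoxy to the bare ring of compound 1 shows a 1.1-fold lower number from compound 1 to compound 4 (0.02 log units; within the scatter). Compound 1, compound 2 and compound 4 therefore cannot be put in any order, while compound 3, with its 4-nitrophenyl, remains the only one that stands apart, now also by a 2.3-fold lower number from compound 3 to compound 4 (0.36 log units; beyond the scatter). Among these four compounds, the hydrogen, chloro and methoxy versions cannot be told apart and nitro is the single exception, and nothing at hand explains this result.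

The compounds shown leave open whether 4-methoxyphenyl or 3-chlorophenyl would match their counterparts here, which would separate the effect of the group from that of its ring position. On these data alone, it also remains open whether an amine, a carboxylic acid or a longer chain such as butoxy on this ring would behave like methoxy or like nitro.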